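The compounds below may be only part of what the source reports. "The series", "measured", "known", "first", "only" and "open" are said of these compounds alone.

Compound 1 `COc1ncnc2c1c(-c1cccs1)cn2[C@@H]1O[C@H](CO)[C@@H](O)[C@H]1O`: in a functional assay on CEM-DNR-bulk cells (Homo sapiens), read by MTT assay, with a stated time of 72 h (a higher number here means a weaker inhibitor, a lower number a stronger inhibitor), compound 1 gives 12100 nM.
Compound 2 `CN(C)c1ncnc2c1c(-c1ccsc1)cn2[C@@H]1O[C@H](CO)[C@@H](O)[C@H]1O`: in this assay compound 2 gives > 20000 nM, which is a limit of the assay and not a number.

Compound 2 therefore sits at the limit of > 20000 nM in this assay, at which 1 of the 2 values shown sits, and no number is known for it. Within the data shown here, compound 1 and compound 2 differ in two places, so their values show only that compound 1 returned a number while compound 2 did not; no step between them can be drawn.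

Compound 3 `CN(C)c1ncnc2c1c(-c1cccs1)cn2[C@@H]1O[C@H](CO)[C@@H](O)[C@H]1O` has not yet been measured. Its structure differs from that of compound 2 in one place: thiophen-2-yl in place of thiophen-3-yl on an aromatic carbon. Compound 1 also carries thiophen-2-yl, and in this assay compound 1 gives 12100 nM, a weak value but a measurable one. With compound 2 known only as a limit, the change is expected to produce an at least 1.1-fold lower number from compound 2 to compound 3 (0.04 log units; that floor lies within the scatter), a small step toward a measurable value rather than one beyond the scatter. Compound 3 is thus estimated at 18000 nM, with a range from 6000 nM to 60000 nM, and it may well again return only a limit.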

Compound 3, half-maximal inhibitory concentration: > 20000 nM
Compound 3 was reported as a limit; the forecaster's own chance of this, stated with the estimate: 50%; middle value at least 1.1-fold (0.04 log units) from the limit.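

In this assay compound 3 gives > 20000 nM, which is a limit of the assay and not a number, and the step from thiophen-3-yl to thiophen-2-yl on the dimethylamino compounds therefore cannot be read. Among these compounds, the same result does provide the first readable step for a single change, at the other substituent on the shared core: dimethylamino in place of methoxy on an aromatic carbon gives an at least 1.6-fold higher number from compound 1 to compound 3 (0.21 log units; that floor lies within the scatter). With thiophen-2-yl held fixed, only the methoxy compound has returned a number so far, and both dimethylamino compounds stop at the same limit: the limit of > 20000 nM in this assay, at which 2 of the 3 values shown sit.

On these data alone, how far compound 2 and compound 3 lie past that limit remains unknown, and so does whether the two thiophene attachments differ at all when the other substituent is dimethylamino. Also open, as far as these compounds go, are whether thiophen-3-yl paired with methoxy would return a number, and what a primary amine or a methyl group would give in place of methoxy or dimethylamino on the same aromatic carbon.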